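Fluoro to dimethylamino: working notes on the series

A few compounds are considered here, and "the series" means these few. Any claim that something is new, unique, unknown or untested is made for them only; others in the source may bear on it.

In a functional assay on P388 cells (Mus musculus) for inhibition (a lower number here means a stronger inhibitor, a higher number a weaker inhibitor), compound 2 `O=C1/C(=C/c2ccc(F)cc2)CCCc2ccccc21` gives 11100 nM and compound 3 `O=C1/C(=C/c2cccc(Cl)c2)CCCc2ccccc21` gives 8200 nM so the two values lie within the scatter of each other. Compound 1 `O=C1/C(=C/c2ccc(Br)cc2)Cc2ccccc21` reads > 50000 nM which is a limit of the assay and not a number. Compound 4 `CN(C)c1ccc(/C=C2\CCCc3ccccc3C2=O)cc1` departs from compound 2 in one place (dimethylamino in place of fluoro on an aromatic carbon) with dimethylamino in place of fluoro on an aromatic carbon, para to a large group. Going by the values given here, no measured pair isolates this change. The estimated step in this assay is a 1.4-fold lower number from compound 2 to compound 4 (0.14 log units; within the scatter) and it is expected to stay within the scatter. For compound 4 the expected value is 8000 nM with an estimated range from 2000 nM to 30000 nM in this assay.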

Compound 4, half-maximal inhibitory concentration: 1900 nM
Beside the measured number, compound 4's estimate is 4.2-fold (0.62 log units) above it; the measured number lies below the stated range.
By their numbers in this assay, from the lowest: compound 4; then compounds 3 and 2 (each within the scatter of the next). At a limit, above all of these: compound 1.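

In this assay, dimethylamino in place of fluoro on an aromatic carbon, para to a large group, gives a 5.8-fold lower number from compound 2 to compound 4 (0.77 log units; beyond the scatter). Going by these compounds alone, this is the first step that can be read, and it shows that this position responds to the change of group and accepts the three heavy atoms of dimethylamino with a lower number. Nothing at hand accounts for the step.

Left open is whether a plain amine, a methoxy group or longer chains on the nitrogen would do the same at this place. Also open, as far as these compounds go, is how dimethylamino behaves on the core of compound 1.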